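A few compounds are considered here, and "the series" means these few. Any claim that something is new, unique, unknown or untested is made for them only; others in the source may bear on it.

Working notes on the series

Compound 1 `Cc1nc(C)c(/C=C/C(=O)/C=C/c2ccccc2O)nc1C` gives 4780 nM in a functional assay on A549 cells (Homo sapiens) for antiproliferative activity, read by MTT assay, with a stated time of 72 h; a higher number here means a weaker inhibitor, a lower number a stronger inhibitor. Compound 2 `COc1cccc(/C=C/C(=O)/C=C/c2nc(C)c(C)nc2C)c1O` differs from it by methoxy in place of hydrogen on an aromatic carbon
in words: methoxy in place of hydrogen on an aromatic carbon
and in this assay compound 2 gives 2850 nM, so the step is a 1.7-fold lower number from compound 1 to compound 2 (0.22 log units; within the scatter).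

Compound 3 `COc1ccc(/C=C/C(=O)/C=C/c2nc(C)c(C)nc2C)cc1` carries a different core; how it differs from compound 1 is not broken down here. In this assay compound 3 gives 3500 nM.

Compound 4 `COc1ccc(/C=C/C(=O)/C=C/c2nc(C)c(C)nc2C)cc1OC` is not yet measured. It differs from compound 3 by methoxy in place of hydrogen on an aromatic carbon
in words: methoxy in place of hydrogen on an aromatic carbon
which is the same kind of change as that from compound 1 to compound 2, though the surroundings differ: in compound 2 the entering group sits ortho to a hydroxy group (1 heavy atom), in compound 4 ortho to a methoxy group (2 heavy atoms). This change occurs twice among the compounds shown.

Going by the values given here, the step from compound 3 to compound 4 is expected to be a 1.4-fold lower number from compound 3 to compound 4 (0.15 log units; within the scatter), resting on the single earlier step of this kind, a 1.7-fold lower number from compound 1 to compound 2 (0.22 log units; within the scatter), which lay within the scatter. Compound 4 is estimated at 2500 nM, between 1200 nM and 5500 nM.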

Compound 4, half-maximal inhibitory concentration: 3790 nM
Estimate against measurement, compound 4: 1.5-fold (0.18 log units) below; the measured number falls inside the stated range.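

In this assay the added methoxy gives a 1.1-fold higher number from compound 3 to compound 4 (0.03 log units; within the scatter), so this step, like the earlier one, stays within the scatter. Set side by side, the two steps do not differ by more than repeated measurement would allow: the same change on two cores in this assay, a 1.7-fold lower number (0.22 log units; within the scatter) from compound 1 to compound 2 and a 1.1-fold higher number (0.03 log units; within the scatter) from compound 3 to compound 4, 1.8-fold (0.26 log units) apart, within the scatter of two such steps. Going by these compounds alone, this gives no sign that the change behaves differently on the two cores, but with only two pairs and steps this small, it does not show that methoxy in place of hydrogen has a real effect on either core, or that any such effect carries from one core to the other.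

The compounds shown leave open whether a group other than hydroxy or methoxy on the aromatic ring, such as an amine, a carboxylic acid or a longer alkoxy chain, would produce a step beyond the scatter. They also leave open whether the methoxy change would give a step beyond the scatter on a core that carries neither of these groups.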